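The source may hold more compounds than are shown below. What is called first, only, known or untested is meant among the compounds shown, and "the series" means these compounds.

Compounds measured in an ADME assay on microsomes from liver (Mus musculus) for metabolic stability, read by LC-MS, using NADPH, with stated times of 6 min and 10 min, tested at 0.5 uM; a higher number here means that more of the compound is left, a lower number that less of the compound is left:
- compound 1 `COc1ccc(-c2cc(Cl)c3c(N)ncnn23)cc1N1CCN(C(C)=O)C(C)(C)C1=O`: 94%
- compound 2 `CC(=O)N1CCN(c2cc(-c3cc(Cl)c4c(N)ncnn34)ccc2C(C)O)C(=O)C1(C)C`: 100%
- compound 3 `CC(=O)N1CCN(c2cc(-c3cc(Cl)c4c(N)ncnn34)ccc2C#N)C(=O)C1(C)C`: 89%

In this assay, compound 3 gives 89%. Its standing against the other two is mixed: the result is a number 5 percentage points lower from compound 1 to compound 3 (within the scatter), and also a number 11 percentage points lower from compound 2 to compound 3 (beyond the scatter). Compound 4 `CC(=O)N1C[C@@H](C)N(c2cc(-c3cc(Cl)c4c(N)ncnn34)ccc2C#N)C(=O)C1(C)C` keeps the cyano group of compound 3 and differs from it by one change: methyl in place of hydrogen on a saturated ring carbon. The measured steps bear on this only indirectly, as all of them change a group on an aromatic carbon and none touches the saturated ring. The other step, a number 6 percentage points higher from compound 1 to compound 2 (within the scatter), is also small. Together they show only that this series stays high in this assay across such changes, and the data hold no direct precedent for a methyl on the saturated ring. A small loss at most is therefore expected, with no firm direction, and the estimate amounts to a number 4 percentage points lower from compound 3 to compound 4 (within the scatter). For compound 4 the estimated value is 85%, with an expected range from 70% to 97%.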

Compound 4, percent of the compound remaining: 22%
Compound 4: middle estimate off by 63 percentage points, on the high side; the measured number lies below the stated range.
By their numbers in this assay, from the lowest: compound 4; then compounds 3, 1 and 2 (each within the scatter of the next, the first and the last beyond it).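

In this assay, a single methyl in place of hydrogen on a saturated ring carbon, next to the ring nitrogen, gives a number 67 percentage points lower from compound 3 to compound 4 (beyond the scatter), a far larger step than any of the changes on the aromatic carbon among compound 1, compound 2 and compound 3. The high numbers of those three compounds therefore say nothing about this saturated ring position, where one added carbon is enough to leave much less of the compound. No measurement at hand gives a reason for this loss.

Going by these compounds, it remains open whether the other configuration at this carbon, or an ethyl or hydroxymethyl group there, would bring the same loss. On these data alone, it is equally open whether the same methyl would do so with the methoxy of compound 1 or the 1-hydroxyethyl of compound 2 in place of cyano.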